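The source may report more compounds than this note shows. Statements on the series, on what has been measured and on what is new or still open speak of the compounds shown alone.

Measured in a functional assay on MCF7 cells (Homo sapiens) for antiproliferative activity, read by CellTiter-Glo, with a stated time of 5 days; on this read-out higher numbers stand for weaker inhibition and lower numbers for stronger inhibition:
- Compound 1 `CC/C(=C(/c1ccc(/C=C/C(=O)O)cc1)c1ccc2cncn2c1)c1ccccc1`: > 500 nM (a limit).
- Compound 2 `CC/C(=C(/c1ccc(/C=C/C(=O)O)cc1)c1ccc2scnc2c1)c1ccccc1`: 90 nM.

Within the data shown here, compound 2 carries the only true number so far, as the other result is a limit. Compound 3 `O=C(O)/C=C/c1ccc(/C(=C(\c2ccccc2)C2CCC2)c2ccc3scnc3c2)cc1` differs from it by cyclobutyl in place of ethyl on a double-bonded chain carbon bound to an aromatic carbon and a double-bonded chain carbon, on a double-bonded chain carbon bound to an aromatic carbon and a double-bonded chain carbon. Among the measured compounds shown here, the one measured step, an at least 5.5-fold lower number from compound 1 to compound 2 (0.74 log units; beyond the scatter), exchanges a different group and keeps the ethyl, so it gives no size for this change. Without such evidence, no shift beyond the scatter is expected in this assay, and the expected step is a 1.5-fold lower number from compound 2 to compound 3 (0.18 log units; within the scatter). For compound 3 the estimate is 60 nM, with an expected range of 15 nM to 250 nM.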

Compound 3, half-maximal inhibitory concentration: 16 nM
Compound 3: middle estimate off by 3.8-fold (0.57 log units), on the high side, within the range that was stated.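

In this assay, among these compounds, cyclobutyl in place of ethyl gives a 5.6-fold lower number from compound 2 to compound 3 (0.75 log units; beyond the scatter) and is the first reading at this position, as compounds 1 and 2 both carry ethyl. The position therefore takes a four-membered non-aromatic ring of carbon only, and the number moves towards stronger inhibition. Nothing in the data shown bears on why the number moves.

As far as these compounds go, whether the shift follows the ring or the added carbons stays open. Isopropyl, cyclopropyl, cyclopentyl or a longer chain such as butyl at this place would separate the two.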